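The compounds below may be only part of what the source reports. "The series", "measured", "known", "first", "only" and "open" are said of these compounds alone.

Working notes on the series.

The shared core is a carbamate with an alkoxy-substituted aryl amine, carried in compound 1 `CCCCCCCCOc1ccc(NC(=O)Oc2ccccc2F)cc1` and compound 2 `CCCCCCCCOc1ccc(NC(=O)Oc2ccccc2)cc1`. Within the data shown here, in an assay on H4 cells for inhibition of Fatty-acid amide hydrolase 1 (Homo sapiens) (a higher number here means a weaker inhibitor, a lower number a stronger inhibitor), compound 1 gives 19 nM, the higher of the two numbers measured so far; its nearest neighbour is compound 2, which in this assay gives 5.4 nM. Among the measured compounds shown here, the only measured step, a 3.5-fold lower number from compound 1 to compound 2 (0.55 log units; beyond the scatter), comes from a single change on the aromatic ring of the phenol part.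

Compound 3 `CCCCCCOc1ccc(NC(=O)Oc2ccccc2F)cc1` departs from compound 1 on the other side of the core: hydrogen in place of ethyl on a saturated chain carbon, six bonds along the chain from an oxygen on an aromatic ring. For the measured compounds named here, no measured step touches this chain; the one step in hand, a 3.5-fold lower number from compound 1 to compound 2 (0.55 log units; beyond the scatter), concerns the aromatic fluorine and gives no guidance on chain length. The expectation for compound 3 therefore rests on the structural change alone and is held loosely, with a slight lean toward a higher number, so that the estimated step is a 2.1-fold higher number from compound 1 to compound 3 (0.32 log units; beyond the scatter). Compound 3 is accordingly estimated at 40 nM, with a range from 10 nM to 160 nM.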

Compound 3, half-maximal inhibitory concentration: 710 nM
The estimate for compound 3 lay 18-fold (1.25 log units) below the measured number; measured number above the stated range.
By their numbers in this assay, from the lowest: compound 2; then compound 1; then compound 3.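

In this assay, the saturated chain on the alkoxy side of the core proves to be a sensitive position: hydrogen in place of ethyl, six bonds along the chain from an oxygen on an aromatic ring, gives a 37-fold higher number from compound 1 to compound 3 (1.57 log units; beyond the scatter). This large step exceeds the modest one seen at the aromatic fluorine, a 3.5-fold lower number from compound 1 to compound 2 (0.55 log units; beyond the scatter), so, among the compounds shown, the removal of ethyl from the chain changes the number more than the removal of fluoro from the phenol part, and the chain end cannot be treated as a passive tail. Nothing available explains why the loss at this position is so large.

The compounds shown leave open whether the number rises gradually or abruptly over the chain lengths between compound 1 and compound 3, which methyl in place of ethyl at the same carbon would address, and whether a longer chain would give a lower number than compound 1. Also open, as far as these compounds go, is whether hydrogen in place of fluoro on the aromatic carbon gives a comparable step when carried out on compound 3 rather than compound 1.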